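The source may hold more compounds than are shown below. What is called first, only, known or untested is meant among the compounds shown, and "the series" means these compounds.

Working notes on the series. In an ADME assay on HepG2 2.2.15 cells (Homo sapiens) for cytotoxicity, read by MTT assay, with a stated time of 8 days (a higher number here means that more compound is tolerated, a lower number that less compound is tolerated), compound 1 (`COC(=O)c1cc(-c2ccc(F)nc2F)nn(Cc2ccc(Cl)cc2)c1=O`) gives > 100000 nM, which is a limit of the assay and not a number. Compound 2 (`CN(C)c1ccc(-c2nn(Cc3ccc(C#N)cc3)c(=O)c3ccccc23)c(F)n1`) has a different core and returns a true number in this assay, 79200 nM. Compound 3 (`COc1cc(-c2ccc(F)nc2F)nn(Cc2ccc(Cl)cc2)c1=O`) keeps the 2,6-difluoropyridin-3-yl group and the 4-chlorobenzyl group of compound 1 and carries methoxy in place of methoxycarbonyl on an aromatic carbon, opposite the ring nitrogen: methoxy in place of methoxycarbonyl on an aromatic carbon. Among the measured compounds shown here, no measured pair isolates this change. No shift beyond the usual scatter is expected, and the reading may well come back as a limit again. Compound 2, with 79200 nM, is the only numeric anchor for this expectation. The expected change is a number no higher from compound 1 to compound 3 (the limit leaves the size open). For compound 3 the estimate is 100000 nM, with an expected range of 45000 nM to 200000 nM.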

Compound 3, half-maximal cytotoxic concentration: 92200 nM
For compound 3 the middle estimate is 1.1-fold (0.04 log units) above the measured one; the range from low to high includes it.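

Methoxy in place of methoxycarbonyl, on this aromatic carbon opposite the ring nitrogen, gives an at least 1.0-fold lower number from compound 1 to compound 3 (0.03 log units; that floor lies within the scatter) in this assay and so provides a true number with the 2,6-difluoropyridin-3-yl and 4-chlorobenzyl groups unchanged. At this position, a group of 2 heavy atoms can stand in place of one of 4 with no shift shown beyond the scatter. Only the floor of the step is known, because one end of it is a limit of the assay: the limit of > 100000 nM in this assay, at which 1 of the 3 values shown sits.

The compounds shown leave open how an amine, a carboxylic acid or a longer chain such as ethoxy at this position would read in this assay and whether any of them would return a number or a limit. They also leave open whether the same change would behave alike on the core of compound 2.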